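Bromo to chloro beside a flat measured pair

The source may hold more compounds than are shown below. What is called first, only, known or untested is meant among the compounds shown, and "the series" means these compounds.

In a functional assay on A549 cells (Homo sapiens) for antiproliferative activity, read by MTT assay, with a stated time of 48 h (a lower number here means a stronger inhibitor, a higher number a weaker inhibitor), compound 1 (`O=C(/C=C/c1ccc(F)cc1)Nc1nnc(-c2ccc(Br)cc2)s1`) gives 2.83 ug/mL. Among the measured compounds shown here, only one other compound has a number there: compound 2 (`O=C(/C=C/c1ccccc1)Nc1nnc(-c2ccc(Br)cc2)s1`) gives 2.18 ug/mL. These two values lie within the scatter of each other, so the standing of compound 1 is not separable from that of compound 2.

The unmeasured compound 3 (`O=C(/C=C/c1ccc(F)cc1)Nc1nnc(-c2ccc(Cl)cc2)s1`) departs from compound 1 at a single place: chloro in place of bromo on an aromatic carbon. Read one bond further out, the same difference is 4-bromophenyl to 4-chlorophenyl. For the measured compounds named here, only one measured step offers any guidance, and only indirectly. That step, a 1.3-fold lower number from compound 1 to compound 2 (0.11 log units; within the scatter), is hydrogen in place of fluoro on an aromatic carbon, and it stays within the scatter. Going by the values given here, no measured step touches the bromo group itself. On this thin evidence, no change beyond the scatter is expected in this assay, and no direction can be called. The expected step is a 1.1-fold lower number from compound 1 to compound 3 (0.04 log units; within the scatter). For compound 3 the estimated value is 2.6 ug/mL, with an expected range of 1.3 ug/mL to 5.2 ug/mL.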

Compound 3, half-maximal inhibitory concentration: 2.06 ug/mL
For compound 3 the middle estimate is 1.3-fold (0.10 log units) above the measured one; measured number inside the range.
By their numbers in this assay, from the lowest: compounds 3, 2 and 1 (each within the scatter of the next).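

In this assay, among the compounds shown here, this is the first reading at the bromo position itself, on an aromatic carbon of a six-membered aromatic ring of carbon only, para to a large group, and chloro in place of bromo gives a 1.4-fold lower number from compound 1 to compound 3 (0.14 log units; within the scatter). The change of 4-bromophenyl to 4-chlorophenyl therefore joins the earlier change at the fluoro group, a 1.3-fold lower number from compound 1 to compound 2 (0.11 log units; within the scatter), so neither of the two single changes made from compound 1 can be separated from the usual variation between repeated measurements. Nothing among the available data bears on why this swap leaves the number within the scatter.

Whether any group at this position can move the number beyond the scatter remains open, since the two halogens shown here say nothing about how an amine, a methoxy group or a carboxylic acid would read in this place. Also open is how the two changes would behave together, in a compound with chloro at this position and hydrogen in place of the fluoro group, which lies outside the compounds shown.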